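The source may hold more compounds than are shown below. What is called first, only, known or untested is meant among the compounds shown, and "the series" means these compounds.

Measured compounds:
Compound 1, `CC(C)S(=O)(=O)Nc1ccc(N(C)S(=O)(=O)c2ccc(F)cc2)cc1`: in a functional assay on the whole organism with Mus musculus as the target, with a stated time of 20 min (a higher number here means that more compound is needed for the effect, a lower number that less compound is needed), compound 1 gives 0.1 mg/kg.
Compound 2, `CCC(=O)N[C@H]1CC[C@@H](NS(=O)(=O)c2ccc(F)cc2)CC1`: compound 2 gives 0.1 mg/kg.
Compound 3, `CC(=O)NC1CCN(S(=O)(=O)c2ccc(F)cc2)CC1`: compound 3 gives 0.01 mg/kg.

Compound 2 stands level with compound 1 at the digits shown, and the two together have the highest numbers of the three; their gap lies within the usual scatter, so no order between them can be read. Compound 3 sits furthest from compound 2, at a markedly lower number, and that gap lies beyond the scatter.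

Compound 4, `CC(=O)N[C@H]1CC[C@@H](NS(=O)(=O)c2ccc(F)cc2)CC1`, differs from compound 2 in one place: hydrogen in place of methyl on a saturated chain carbon bound to a carbonyl carbon. Among the compounds with values here, no pair of measured compounds shows this change by itself. Compound 3 does carry the acetamido group, but on a different core with further changes, so its value cannot be read as the effect of this change alone. With only this to go on, a small step is expected from compound 2 to compound 4, one that may not reach beyond the scatter, with at most a slight lean toward a lower number in this assay. The expected step is a 1.4-fold lower number from compound 2 to compound 4 (0.15 log units; within the scatter). Compound 4 is therefore estimated at 0.07 mg/kg, within a range from 0.02 mg/kg to 0.3 mg/kg.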

Compound 4, minimum effective dose: 1 mg/kg
The estimate for compound 4 lay 14-fold (1.15 log units) below the measured number, and the stated range ends below it.
By their numbers in this assay, from the lowest: compound 3; then compounds 1 and 2 (each within the scatter of the next); then compound 4.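

In this assay, the change from propanoylamino to acetamido gives a 10-fold higher number from compound 2 to compound 4 (1.00 log units; beyond the scatter), and this step lies beyond the scatter. Within the data shown here, until now, no two compounds differed in one place, so this pair gives the first reading of a single change. It shows that this position, a saturated chain carbon bound to a carbonyl carbon, is sensitive in this assay: losing one methyl, a single carbon with no hydrogen-bond donor or acceptor and no net charge, means that more compound is needed for the effect.

As this is one pair, the compounds shown cannot tell whether the number would go on falling with a longer chain such as butanoyl, whether a branched chain, an amine or a carboxylic acid at this place would be tolerated, or whether the same step would appear on any other core. Nothing given here bears on what lies behind the step.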